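The source may report more compounds than this note shows. Statements on the series, on what has been measured and on what is new or still open speak of the compounds shown alone.

Measured compounds in an assay on isolated protein for inhibition of histone deacetylase 4 (Homo sapiens), with a stated time of 1 h; a lower number here means a stronger inhibitor, a higher number a weaker inhibitor:
- compound 1 `O=C(COc1ccc2cc(/C=C3/SC(=O)NC3=O)ccc2c1)Nc1ccc(Br)cc1F`: 1900 nM
- compound 2 `O=C(COc1ccc2cc(/C=C3/SC(=O)NC3=O)ccc2c1)Nc1ccccn1`: 17000 nM
- compound 3 `O=C(COc1ccc2cc(/C=C3/SC(=O)NC3=O)ccc2c1)Nc1cccc(F)n1`: 840 nM

Compound 1 sits second highest of the three numbers; compound 3 is nearest, compound 2 furthest. Compound 4 `O=C(COc1ccc2cc(/C=C3/SC(=O)NC3=O)ccc2c1)Nc1ccccc1` is compound 1 with phenyl in place of 4-bromo-2-fluorophenyl on an amide-type nitrogen. Among the compounds with values here, two measured steps bear on this. Swapping the same halogenated ring for a ring without halogens gave an 8.9-fold higher number from compound 1 to compound 2 (0.95 log units; beyond the scatter), while the step of a 20-fold lower number from compound 2 to compound 3 (1.31 log units; beyond the scatter) shows that a single fluorine on the ring carried most of that difference. Stripping both halogens from compound 1 is therefore expected to raise the number in this assay by a modest to large step, a 3.4-fold higher number from compound 1 to compound 4 (0.53 log units; beyond the scatter). For compound 4 the estimate is 6500 nM, within a range of 2000 nM to 20000 nM.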

Compound 4, half-maximal inhibitory concentration: 2100 nM
Beside the measured number, compound 4's estimate is 3.1-fold (0.49 log units) above it; the measured number falls inside the stated range.
By their numbers in this assay, from the lowest: compound 3; then compounds 1 and 4 (each within the scatter of the next); then compound 2.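

In this assay, taking both halogens off the ring on the amide-type nitrogen leaves the number within the scatter, a 1.1-fold higher number from compound 1 to compound 4 (0.04 log units; within the scatter), so on this carbon-only ring the pair of halogens makes no measurable difference. The ring itself does matter: phenyl gives a stronger inhibitor than pyridin-2-yl, an 8.1-fold lower number from compound 2 to compound 4 (0.91 log units; beyond the scatter), yet a weaker one than 6-fluoropyridin-2-yl, a 2.5-fold higher number from compound 3 to compound 4 (0.40 log units; beyond the scatter). Nothing measured here explains these shifts. Still open, from the compounds shown here alone, is how a single fluoro or bromo, or an amine or a carboxylic acid, on the phenyl ring would change the number.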